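A few compounds are considered here, and "the series" means these few. Any claim that something is new, unique, unknown or untested is made for them only; others in the source may bear on it.

Two compounds share one core and differ only in the group carried on the aromatic ring. Compound 1, `CC(C)(C)OC(=O)NCCNC(=O)CN1CN(c2ccccc2)C2(CCN(C(=O)c3ccc(C(C)(C)C)cc3)CC2)C1=O`, gives 10900 nM in an assay on HEK293 cells for displacement of a labelled ligand from NPC1-like intracellular cholesterol transporter 1 (Homo sapiens); on this read-out higher numbers stand for weaker inhibition and lower numbers for stronger inhibition. Compound 2, `CC(C)(C)OC(=O)NCCNC(=O)CN1CN(c2ccccc2)C2(CCN(C(=O)c3ccc(C4CCCCC4)cc3)CC2)C1=O`, gives 5500 nM in this assay. The step of a 2.0-fold lower number from compound 1 to compound 2 (0.30 log units; within the scatter) lies within the scatter, so the two compounds stand level; compound 2 carries the lower of the two numbers, but the measurements cannot tell the two apart.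

Compound 3, `CC(C)(C)OC(=O)NCNC(=O)CN1CN(c2ccccc2)C2(CCN(C(=O)c3ccc(C4CCCCC4)cc3)CC2)C1=O`, alters a different part of the molecule: (tert-butoxycarbonyl)amino in place of ((tert-butoxycarbonyl)amino)methyl on a saturated chain carbon bound to an amide-type nitrogen. The chain linking the two amide-type groups thus becomes shorter, while the aromatic ring still carries the cyclohexyl of compound 2.

Within the data shown here, no measured pair probes this chain; the single measured step concerns only the aromatic substituent and is itself within the scatter. Nothing in the data therefore points to a step in either direction for compound 3, and the expected step of no change at the digits printed from compound 2 to compound 3 (within the scatter) is none beyond the scatter. Compound 3 is estimated at 5500 nM in this assay, with a range from 2500 nM to 12000 nM.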

Compound 3, half-maximal inhibitory concentration: 1700 nM
Compound 3: middle estimate off by 3.2-fold (0.51 log units), on the high side; measured number outside the range, below it.
By their numbers in this assay, from the lowest: compound 3; then compounds 2 and 1 (each within the scatter of the next).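

Replacing ((tert-butoxycarbonyl)amino)methyl with (tert-butoxycarbonyl)amino on a saturated chain carbon bound to an amide-type nitrogen gives a 3.2-fold lower number from compound 2 to compound 3 (0.51 log units; beyond the scatter) in this assay, and this is the first step among these compounds that lies beyond the scatter. The change is small on paper: the entering group has 5 carbon atoms where the leaving group has 6, while its nitrogen, its oxygens and its counts of hydrogen-bond donors and acceptors stay the same, so this chain is a place where a slight edit separates two compounds, which the aromatic substituent change did not do. The data shown offer no measurement that explains why the shorter chain goes with stronger inhibition.

Among these compounds, the shortening is seen only with cyclohexyl on the aromatic ring, so whether it would give a similar step with tert-butyl there remains open. Also open, going by these compounds, is how this position would respond to a longer chain than the 2-((tert-butoxycarbonyl)amino)ethyl group, or to a free amine in place of the tert-butoxycarbonyl-protected one.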